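From Dimethylamino to Formyl on the Shared Core

A few compounds are considered here, and "the series" means these few. Any claim that something is new, unique, unknown or untested is made for them only; others in the source may bear on it.

In a functional assay on ML1 cells (Homo sapiens) for antiproliferative activity, read by WST assay, with a stated time of 3 days (on this read-out higher numbers stand for weaker inhibition and lower numbers for stronger inhibition), compound 1 (`CNc1cc(=O)[nH]c(=O)n1[C@@H]1O[C@H](CO)[C@@H](O)[C@H]1O`) gives > 50000 nM as a limit and not a number. Compound 2 (`CN(C)c1cc(=O)[nH]c(=O)n1[C@@H]1O[C@H](CO)[C@@H](O)[C@H]1O`) gives > 50000 nM as a limit too, so its place is known only as the limit of > 50000 nM in this assay, at which 2 of the 2 values shown sit, and no more. Compound 3 (`O=Cc1cc(=O)[nH]c(=O)n1[C@@H]1O[C@H](CO)[C@@H](O)[C@H]1O`) carries formyl in place of dimethylamino on an aromatic carbon is the change. Among the measured compounds shown here, the only measured step, a step that the two limits leave unreadable from compound 1 to compound 2 in size, concerns another change and offers no measure. In this assay little change is therefore expected, with any shift toward stronger inhibition. The estimated step of an at least 1.4-fold lower number from compound 2 to compound 3 (0.15 log units; that floor lies within the scatter) is expected to be modest. Compound 3 is estimated at 35000 nM within an expected range of 5000 nM to 100000 nM in all.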

Compound 3, half-maximal inhibitory concentration: > 50000 nM
Compound 3 gave a limit, no number; the forecaster's own chance of this, stated with the estimate: 60%; at least 1.4-fold (0.15 log units) between middle value and limit.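

Compound 3 also gives only a limit, like compound 1 and compound 2, so no step among the three can be read in this assay: the limit of > 50000 nM in this assay, at which 3 of the 3 values shown sit.

The compounds shown leave open whether methylamino, dimethylamino or formyl on the shared core differ at all in inhibition.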